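Aryl hydrazone swap on a pyrimidine-fused dione core

The compounds below may be only part of what the source reports. "The series", "measured", "known", "first", "only" and "open" are said of these compounds alone.

Three analogues sharing one core have been measured in a functional assay on PC-3 cells (Homo sapiens) for antiproliferative activity, read by MTT assay; a lower number here means a stronger inhibitor, a higher number a weaker inhibitor: compound 1 `Cn1c(=O)c(=O)n(C2CCCC2)c2nc(N/N=C/c3ccccc3)ncc21` gives 48200 nM, compound 2 `Cn1c(=O)c(=O)n(C2CCCC2)c2nc(N/N=C/c3cccc(Cl)c3Cl)ncc21` gives 17200 nM, and compound 3 `Cn1c(=O)c(=O)n(C2CCCC2)c2nc(N/N=C/c3ccco3)ncc21` gives 72200 nM. Compound 3 carries the highest number of the three, though one of the steps leading to it, a 1.5-fold higher number from compound 1 to compound 3 (0.18 log units; within the scatter), is within the scatter, while a 4.2-fold higher number from compound 2 to compound 3 (0.62 log units; beyond the scatter) lies beyond it. Compound 4 `Cc1cc(C)c(/C=N/Nc2ncc3c(n2)n(C2CCCC2)c(=O)c(=O)n3C)c(C)c1` differs from compound 3 by 2,4,6-trimethylphenyl in place of furan-2-yl on a carbon with a double bond to nitrogen. The bearing steps are a 1.5-fold higher number from compound 1 to compound 3 (0.18 log units; within the scatter) and a 4.2-fold higher number from compound 2 to compound 3 (0.62 log units; beyond the scatter); a six-membered carbon ring in place of the furan-2-yl gave a lower number in both, modestly so for the chlorinated one. Compound 4 is therefore expected to give a modestly lower number, a 2.9-fold lower number from compound 3 to compound 4 (0.46 log units; beyond the scatter), with an estimate of 25000 nM and a range from 8000 nM to 80000 nM in this assay.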

Compound 4, half-maximal inhibitory concentration: 13900 nM
Beside the measured number, compound 4's estimate is 1.8-fold (0.25 log units) above it, within the range that was stated.
By their numbers in this assay, from the lowest: compounds 4 and 2 (each within the scatter of the next); then compounds 1 and 3 (each within the scatter of the next).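

In this assay, the 2,4,6-trimethylphenyl group on the carbon with a double bond to nitrogen gives a clearly lower number than furan-2-yl (a 5.2-fold lower number from compound 3 to compound 4 (0.72 log units; beyond the scatter)) and than phenyl (a 3.5-fold lower number from compound 1 to compound 4 (0.54 log units; beyond the scatter)). Against 2,3-dichlorophenyl the difference stays within the scatter (a 1.2-fold lower number from compound 2 to compound 4 (0.09 log units; within the scatter)), so among these compounds, a lower number at this place does not depend on chlorine. Nothing shown here accounts for these differences.

From the compounds shown here alone, it remains open whether a single methyl on the phenyl would be enough. Going by these compounds, how a phenyl carrying an amine or a carboxylic acid would behave at this place is also open.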